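This account rests on a few compounds, and the source may have more. Where it says the series, first, only, none or still open, it means among the compounds named here.

In an ADME assay on MDBK cells (Bos taurus) for cytotoxicity, read by MTT assay, with a stated time of 96 h (a higher number here means that more compound is tolerated, a lower number that less compound is tolerated), the measured compounds stand as follows.
Compound 1 `Cn1c(-c2ccc([N+](=O)[O-])cc2)nc2cc(C(F)(F)F)ccc21` reaches only a limit, > 100000 nM.
Compound 2 `Cn1c(-c2ccc(N)cc2)nc2cc(C(F)(F)F)ccc21` gives 74000 nM.
Compound 3 `COc1ccc(-c2nc3cc(C(F)(F)F)ccc3[nH]2)c([N+](=O)[O-])c1` gives 55000 nM.

Compound 1 sits at the limit of > 100000 nM in this assay, at which 1 of the 3 values shown sits. From compound 1 to compound 2 the change is amino in place of nitro on an aromatic carbon, and the step in this assay is an at least 1.3-fold lower number from compound 1 to compound 2 (0.13 log units; that floor lies within the scatter). The values of compound 2 and compound 3 lie within the scatter of each other. How the core of compound 3 differs from the core of compound 1 is not broken down here. Compound 4 `COc1ccc(-c2nc3cc(C(F)(F)F)ccc3[nH]2)c(N)c1` has not yet been measured; it differs from compound 3 by amino in place of nitro on an aromatic carbon. This is the same kind of change as from compound 1 to compound 2, though here the place is ortho to a large group and meta to a methoxy group rather than para to a large group. Resting on an at least 1.3-fold lower number from compound 1 to compound 2 (0.13 log units; that floor lies within the scatter), a similarly small step is expected from compound 3 to compound 4 in this assay, a 1.2-fold lower number from compound 3 to compound 4 (0.09 log units; within the scatter). Compound 4 is therefore estimated at 45000 nM, between 20000 nM and 95000 nM.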

Compound 4, half-maximal cytotoxic concentration: 4000 nM
The estimate for compound 4 lay 11-fold (1.05 log units) above the measured number; measured number below the stated range.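

In this assay amino in place of nitro on an aromatic carbon gives a 14-fold lower number from compound 3 to compound 4 (1.14 log units; beyond the scatter) and this is a large step on that core. Whether the step carries over unchanged from one core to the other stays undecided: the same change on two cores in this assay, an at least 1.3-fold lower number (0.13 log units; that floor lies within the scatter) from compound 1 to compound 2 and a 14-fold lower number (1.14 log units; beyond the scatter) from compound 3 to compound 4; the limit leaves it open whether they differ. The earlier step therefore rests on a limit and not on a number: the limit of > 100000 nM in this assay, at which 1 of the 4 values shown sits.

The compounds shown leave open whether a hydroxyl group, an amide or a nitrile in the place of the amino group would give a step of similar size on either core. They also leave open how the amino compound on the core of compound 3 would stand without its methoxy group.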